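This account rests on a few compounds, and the source may have more. Where it says the series, first, only, none or still open, it means among the compounds named here.

For the measured compounds named here, compound 3 `Cc1ccc(-n2nncc2CN2C(=O)C3(C(C#N)=C(N)Oc4c(N)cc5nc6ccccc6nc5c43)c3ccccc32)cc1Cl` gives 11800 nM in a functional assay on A549 cells (Homo sapiens) for antiproliferative activity, read by MTT assay, with a stated time of 48 h (a lower number here means a stronger inhibitor, a higher number a weaker inhibitor), the lowest of the three numbers measured so far. Compound 1 `N#CC1=C(N)Oc2c(N)cc3nc4ccccc4nc3c2C12C(=O)N(Cc1cnnn1-c1ccccc1Cl)c1ccccc12` gives 29800 nM and compound 2 `COc1ccc(OC)c(-n2nncc2CN2C(=O)C3(C(C#N)=C(N)Oc4c(N)cc5nc6ccccc6nc5c43)c3ccccc32)c1` gives 28100 nM in this assay; the step of a 1.1-fold lower number from compound 1 to compound 2 (0.03 log units; within the scatter) stays within the scatter. The two steps that lead to compound 3, a 2.5-fold lower number from compound 1 to compound 3 (0.40 log units; beyond the scatter) and a 2.4-fold lower number from compound 2 to compound 3 (0.38 log units; beyond the scatter), are the only ones beyond the scatter and both are modest. Compound 4 `N#CC1=C(N)Oc2c(N)cc3nc4ccccc4nc3c2C12C(=O)N(Cc1cnnn1-c1ccc([N+](=O)[O-])cc1[N+](=O)[O-])c1ccccc12` carries the change (2,4-dinitrophenyl in place of 3-chloro-4-methylphenyl on an aromatic nitrogen). Going by the values given here, the aromatic group on this aromatic nitrogen is the one place varied across the set, and the three measured variants span a narrow band of numbers; none of them carries a nitro group, so no measured step covers the 2,4-dinitrophenyl entrant directly. The expectation is a drift back toward the numbers of compound 1 and compound 2, so the step from compound 3 to compound 4 is expected to be a 1.7-fold higher number from compound 3 to compound 4 (0.23 log units; within the scatter), modest and upward rather than anything larger. Compound 4 is estimated at 20000 nM in this assay, within a range from 8000 nM to 60000 nM.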

Compound 4, half-maximal inhibitory concentration: > 50000 nM
Compound 4: no number, only a limit (the forecaster's own chance of this, stated with the estimate: 10%); middle value at least 2.5-fold (0.39 log units) from the limit.
By their numbers in this assay, from the lowest: compound 3; then compounds 2 and 1 (each within the scatter of the next). At a limit, above all of these: compound 4.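

For the compounds shown here, compound 4, with 2,4-dinitrophenyl on the aromatic nitrogen, is the first in this assay to give a limit and not a number: the limit of > 50000 nM in this assay, at which 1 of the 4 values shown sits. Against 3-chloro-4-methylphenyl the change can be read, an at least 4.2-fold higher number from compound 3 to compound 4 (0.62 log units; beyond the scatter), so this position is not confined to the narrow band of the three earlier variants, and the advantage of compound 3 does not survive this exchange. The other two steps, an at least 1.7-fold higher number from compound 2 to compound 4 (0.25 log units; that floor lies within the scatter) and an at least 1.6-fold higher number from compound 1 to compound 4 (0.22 log units; that floor lies within the scatter), give only floors, so they do not establish a separation from the 2,5-dimethoxyphenyl and 2-chlorophenyl variants.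

From the compounds shown here alone, the true number for compound 4 remains unknown. Also open, going by these compounds, are whether a single nitro group would behave like the pair, and what an amine or a carboxylic acid on this phenyl ring would give.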